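Solubility notes: oxan-3-yl ether in place of ethyl ether

A few compounds are considered here, and "the series" means these few. Any claim that something is new, unique, unknown or untested is made for them only; others in the source may bear on it.

Measured so far:
Compound 1, `CCOc1cc(-c2ccnc(N)n2)cc2[nH]nc(N)c12`, gives 861000 nM in a physicochemical assay for solubility, read by LC-MS, in phosphate buffer, measured as kinetic solubility, with a stated time of 24 h, at 25 degrees C, at pH 7.4; on this read-out higher numbers stand for higher solubility and lower numbers for lower solubility.
Compound 2, `Nc1nccc(-c2ccc3c(Nc4ccccc4)n[nH]c3c2)n1`, gives 3000 nM in this assay.

Compound 1 holds the higher of the two numbers; compound 2 sits far lower, and that gap lies well beyond the scatter. Within the data shown here, no pair of measured compounds differing in one place is available, so the series gives no direct guide for the change to compound 3, `Nc1nccc(-c2cc(OC3CCCOC3)c3c(N)n[nH]c3c2)n1`, which remains to be measured. The change from compound 1 to compound 3 is oxan-3-yl in place of ethyl on an oxygen on an aromatic ring. Among the measured compounds shown here, with no comparable step to draw on, the expectation for compound 3 in this assay is a modest step down from compound 1, or none beyond the scatter. The estimated step is a 1.7-fold lower number from compound 1 to compound 3 (0.24 log units; within the scatter). Compound 3 is expected to give 500000 nM in this assay, within a range of 150000 nM to 1000000 nM.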

Compound 3, solubility: 1000000 nM
Beside the measured number, compound 3's estimate is 2.0-fold (0.30 log units) below it; the range from low to high includes it.
By their numbers in this assay, from the lowest: compound 2; then compounds 1 and 3 (each within the scatter of the next).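

In this assay, among these compounds, the exchange of ethoxy for (oxan-3-yl)oxy on an oxygen on an aromatic ring gives a 1.2-fold higher number from compound 1 to compound 3 (0.06 log units; within the scatter), the only step available at this position. This place in the core of compound 1 therefore accepts oxan-3-yl, with its six-membered non-aromatic ring and its hydrogen-bond acceptor, in place of ethyl, with the read-out staying within the scatter. No measurement available here explains why the two numbers stay this close.

Going by these compounds, it remains open whether a cyclohexyl group, which has no ring oxygen, would leave the read-out equally unmoved, and so whether the ring oxygen of oxan-3-yl plays any part. Also open, on these data alone, is how groups of another kind on this oxygen, such as a chain ending in an amine, a carboxylic acid or a longer alkyl chain, would read in this assay.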